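The compounds below may be only part of what the source reports. "The series", "measured", "known", "first", "only" and "open" are said of these compounds alone.

Compound 3 `CCN(Cc1ccc(F)cc1)c1cccc(C(=O)N2CCc3ccc(OS(N)(=O)=O)cc3C2)c1` stands lowest of the three measured compounds in an assay on HEK293 cells for inhibition of Steryl-sulfatase (Homo sapiens), tested at 0.1 uM; a lower number here means a weaker effect, a higher number a stronger effect of the compound at the concentration tested: compound 3 gives 10.9%. Compound 1 `CCN(Cc1cccnc1)c1ccc(C(=O)N2CCc3ccc(OS(N)(=O)=O)cc3C2)cc1` gives 35.7% and compound 2 `CCN(Cc1ccccn1)c1ccc(C(=O)N2CCc3ccc(OS(N)(=O)=O)cc3C2)cc1` gives 42.5%; the step of a number 6.8 percentage points higher from compound 1 to compound 2 (within the scatter) lies within the scatter. Compound 3 lies beyond the scatter under both, with compound 1 as its nearest neighbour.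

Compound 4 `CC(C)CCN(CCC(C)C)c1cccc(C(=O)N2CCc3ccc(OS(N)(=O)=O)cc3C2)c1` differs from compound 3 by diisopentylamino in place of ethyl(4-fluorobenzyl)amino on an aromatic carbon. Among the measured compounds shown here, no measured step bears directly on this change: the only measured step, a number 6.8 percentage points higher from compound 1 to compound 2 (within the scatter), exchanges one six-membered aromatic ring for another on the saturated chain carbon, whereas the change to compound 4 removes the aromatic ring from the amine altogether and replaces the whole ethyl(4-fluorobenzyl)amino group by diisopentylamino. All three measured compounds carry an aromatic ring on that nitrogen, so nothing measured shows how an amine without a ring behaves in this assay. In the absence of a relevant step, the expectation for compound 4 is no step beyond the scatter, so a number 2.1 percentage points higher from compound 3 to compound 4 (within the scatter) is expected to be small. Compound 4 is estimated at 13%, in the range 0% to 32%.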

Compound 4, a percentage reported as inhibition, at one concentration (the size of the read-out at that concentration, not a potency): 32.3%
Estimate against measurement, compound 4: 19.3 percentage points below, and the stated range ends below it.
By their numbers in this assay, from the lowest: compound 3; then compounds 4, 1 and 2 (each within the scatter of the next, the first and the last beyond it).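

In this assay, replacing ethyl(4-fluorobenzyl)amino with diisopentylamino on this aromatic carbon gives a number 21.4 percentage points higher from compound 3 to compound 4 (beyond the scatter) and so shows, for this pair, that inhibition at the tested concentration does not depend on an aromatic ring on the amine. The change keeps the count of heavy atoms and hydrogen-bond acceptors, while the six-membered aromatic ring and the fluorine leave. No available evidence explains this step.

Since both substituents on the nitrogen change at once, the pair cannot show whether the rise follows from losing the 4-fluorobenzyl group, losing the ethyl group or gaining the isopentyl chains. Also open, from the compounds shown here alone, are how diethylamino, a piperidine or a morpholine would behave here, and whether diisopentylamino would give a similar step at the attachment point found in compounds 1 and 2.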